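This account rests on a few compounds, and the source may have more. Where it says the series, first, only, none or still open, it means among the compounds named here.

Measured compounds:
- Compound 1, `O=c1ccc2cc(OCc3cn(-c4cccc(CO)c4)nn3)ccc2o1`, result in a functional assay on HL-60 cells (Homo sapiens) for cytotoxicity, read by MTT assay, with a stated time of 48 h; on this read-out lower numbers stand for stronger inhibition and higher numbers for weaker inhibition: "not determined" (no result reported).
- Compound 2, `N#Cc1ccccc1-n1cc(COc2ccc3oc(=O)ccc3c2)nn1`, in this assay 52100 nM.

Within the data shown here, compound 2 is the only compound here with a number; compound 1 was included but gave no result, so there is nothing to set against compound 2 and no step between measured compounds can be drawn.

Compound 3, `COc1ccccc1-n1cc(COc2ccc3oc(=O)ccc3c2)nn1`, is the next compound. The change from compound 2 to compound 3 is methoxy in place of cyano on an aromatic carbon, in words methoxy in place of cyano on an aromatic carbon. Among the measured compounds shown here, with no measured step to lean on, the expectation rests only on the single number for compound 2, which is a weak one, and on the change being small. The expected step is a 1.0-fold lower number from compound 2 to compound 3 (0.02 log units; within the scatter), meaning no change beyond the usual scatter in either direction. Compound 3 is therefore estimated at 50000 nM, with a range from 20000 nM to 125000 nM.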

Compound 3, half-maximal inhibitory concentration: 55200 nM
Compound 3: middle estimate off by 1.1-fold (0.04 log units), on the low side; measured number inside the range.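

In this assay the exchange of 2-cyanophenyl for 2-methoxyphenyl gives a 1.1-fold higher number from compound 2 to compound 3 (0.03 log units; within the scatter) and so leaves the two compounds within the usual scatter of each other. Among these compounds, this is the first readable comparison at this aromatic carbon, ortho to a large group, and it shows that cyano and methoxy cannot be told apart here. Both groups have the same heavy-atom count, and each has one hydrogen-bond acceptor and no donor, but nothing measured here explains why they read alike.

On these data alone, whether this position responds to any change at all remains open, since only these two groups can be compared. An amine, a carboxylic acid or a longer alkoxy chain at the same carbon could give a similar number or a very different one.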